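This account rests on a few compounds, and the source may have more. Where it says the series, first, only, none or still open, it means among the compounds named here.

Three compounds have been measured so far:

Compound 1, `O=C(O)CCc1ccc(OCc2cccc(-c3ccccc3)c2)cc1`, gives 135 nM in a functional assay on 1321-N1 cells for agonist activity at Free fatty acid receptor 1 (Homo sapiens), read by calcium flux; a higher number here means that more compound is needed for the effect, a lower number that less compound is needed.
Compound 2, `O=C(O)CCc1ccc(NCc2cccc(-c3ccccc3)c2)cc1`, gives 53.7 nM in this assay.
Compound 3, `Cc1ccc(-c2cccc(COc3ccc(CCC(=O)O)cc3)c2)cc1`, gives 490 nM in this assay.

Compound 2 stands lowest of the three, and its steps to compound 1 and compound 3 are both beyond the scatter. How compound 2 differs from compound 1 in its core is not broken down here.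

Compound 3 differs from compound 1 by a single change, (methyl in place of hydrogen on an aromatic carbon). That change produced a 3.6-fold higher number from compound 1 to compound 3 (0.56 log units; beyond the scatter), a modest but clear rise in the amount of compound needed.

The unmeasured compound 4, `Cc1ccc(-c2cccc(CNc3ccc(CCC(=O)O)cc3)c2)cc1`, carries the same change on the core of compound 2: methyl in place of hydrogen on an aromatic carbon. The place is described in identical words for both pairs, so this is the same change, made once on each core.

Going by the values given here, the expectation for compound 4 rests on the step of a 3.6-fold higher number from compound 1 to compound 3 (0.56 log units; beyond the scatter), since that is the only measured instance of this change. Compound 4 is therefore expected to move from compound 2 by a 3.5-fold higher number from compound 2 to compound 4 (0.55 log units; beyond the scatter). Compound 4 is estimated at 190 nM in this assay, with a likely range from 80 nM to 500 nM.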

Compound 4, half-maximal effective concentration: 126 nM
Compound 4: middle estimate off by 1.5-fold (0.18 log units), on the high side; the measured number falls inside the stated range.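

Made a second time, the change from phenyl to 4-methylphenyl gave a 2.3-fold higher number from compound 2 to compound 4 (0.37 log units; beyond the scatter) in this assay, so more compound was again needed for the effect. This step runs in the same direction as the earlier one, and the two agree in size as closely as repeated measurements can show, so the change carried over from one core to the other: the same change on two cores in this assay, a 3.6-fold higher number (0.56 log units; beyond the scatter) from compound 1 to compound 3 and a 2.3-fold higher number (0.37 log units; beyond the scatter) from compound 2 to compound 4, 1.5-fold (0.19 log units) apart, within the scatter of two such steps. Going by these compounds alone, the agreement rests on only two pairs of compounds, so it does not show that the methyl would act alike on any other core, nor does it explain why the number rises.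

The compounds shown leave open whether an ethyl group, a chlorine atom or a methoxy group in the place of this methyl would also raise the number. Also open, on these data alone, is how either core would respond to a longer chain carrying the carboxylic acid.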